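Swapping the benzyl halogen pattern on a pyrazole hydroxamate

The compounds below may be only part of what the source reports. "The series", "measured", "known", "first", "only" and "open" are said of these compounds alone.

Measured compounds:
compound 1, `O=C(NOCc1ccc(Cl)cc1Cl)c1cn(-c2ccccc2)nc1-c1ccccc1`, 40200 nM
compound 2, `Cc1ccc(-c2nn(-c3ccccc3)cc2C(=O)NOCc2ccc(Cl)cc2Cl)cc1`, 39600 nM
compound 3, `O=C(NOCc1ccccc1F)c1cn(-c2ccccc2)nc1-c1ccc(F)cc1`, 147000 nM

In an ADME assay on HEK-293T cells (Homo sapiens) for antiproliferative activity, read by MTT assay, with a stated time of 48 h, in the presence of a further agent that is not named here (a higher number here means that more compound is tolerated, a lower number that less compound is tolerated), compound 3 stands highest of the three, beyond the scatter from both compound 1 and compound 2. Compound 4, `O=C(NOCc1ccc(Cl)cc1Cl)c1cn(-c2ccccc2)nc1-c1ccc(F)cc1`, differs from compound 3 by 2,4-dichlorophenyl in place of 2-fluorophenyl on a saturated chain carbon bound to an oxygen, which gives it the same 2,4-dichlorobenzyl group that compounds 1 and 2 carry. For the measured compounds named here, no measured step covers this change directly; the only step recorded, a 1.0-fold lower number from compound 1 to compound 2 (0.01 log units; within the scatter), concerns the other aryl ring and shows no effect. Compound 4 is therefore expected to fall near compounds 1 and 2, a step of a 3.3-fold lower number from compound 3 to compound 4 (0.51 log units; beyond the scatter), with an estimate of 45000 nM and a range from 20000 nM to 110000 nM in this assay.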

Compound 4, half-maximal cytotoxic concentration: 45000 nM
The estimate for compound 4 equals the measured number at the digits printed; measured number inside the range.
By their numbers in this assay, from the lowest: compounds 2, 1 and 4 (each within the scatter of the next); then compound 3.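

In this assay, for the compounds shown here, this is the first measured change at the saturated chain carbon bound to an oxygen: 2,4-dichlorophenyl in place of 2-fluorophenyl gives a 3.3-fold lower number from compound 3 to compound 4 (0.51 log units; beyond the scatter) and is a modest step. With 2,4-dichlorobenzyl held constant, the other aryl ring stays silent for fluoro as well, with a 1.1-fold higher number from compound 1 to compound 4 (0.05 log units; within the scatter) and a 1.1-fold higher number from compound 2 to compound 4 (0.06 log units; within the scatter) as steps that lie within the scatter. Nothing available explains the step at the benzyl group. The compounds shown leave open how a benzyl group with a single chlorine or no halogen would stand. They also leave open what a longer alkyl chain would do at this position.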